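The source may hold more compounds than are shown below. What is called first, only, known or untested is meant among the compounds shown, and "the series" means these compounds.

Measured compounds:
- compound 1, `CC1=CC[C@H](C(C)C)c2cc(C)c(OC(=O)c3ccc(C)cc3)cc21`, 78.9%
- compound 2, `Cc1cc2c(C(C)C)ccc(C)c2cc1OC(=O)c1cccc(C(F)(F)F)c1`, "not active" (no number reported)
- compound 3, `COc1cccc(C(=O)Oc2cc3c(C)ccc(C(C)C)c3cc2C)c1`, 35.2%

Three esters have been tested in a functional assay on HCT-15 cells (Homo sapiens) for antiproliferative activity, read by sulforhodamine B assay, with a stated time of 48 h, tested at 50 uM; on this read-out lower numbers stand for less inhibition and higher numbers for more inhibition at the one concentration tested (going by the name of the read-out). Compound 1 gives the highest of the two numbers reported there, 78.9%. Its nearest neighbour by value is compound 3, which in this assay gives 35.2%, a gap beyond the usual scatter. Compound 2 is reported in this assay only as "not active" (no number reported), without a number. Among the measured compounds shown here, compound 2 and compound 3 share a fully aromatic core that differs from the core of compound 1, so no single-point step between any two measured compounds can be drawn.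

The next compound, compound 4 `CC1=CC[C@H](C(C)C)c2cc(C)c(OC(=O)c3ccc(C(F)(F)F)cc3)cc21`, keeps the core and ester of compound 1 and changes one substituent on the aromatic ring of the acid part: trifluoromethyl in place of methyl on an aromatic carbon. For the measured compounds named here, no measured pair shows what this exchange does on its own, so the expected step rests on the spread of the three values alone. Given that compound 1 gives 78.9% while compound 3 gives 35.2% and compound 2 is reported as "not active" (no number reported), a downward step from compound 1 to compound 4 of modest size is expected, a number 18.9 percentage points lower from compound 1 to compound 4 (beyond the scatter), with wide uncertainty. Compound 4 is accordingly estimated to give about 60% in this assay, within a range from 25% to 85%.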

Compound 4, a percentage reported as inhibition, at one concentration (the size of the read-out at that concentration, not a potency): 6.4%
Estimate against measurement, compound 4: 53.6 percentage points above, and the stated range ends above it.
By their numbers in this assay, from the lowest: compound 4; then compound 3; then compound 1.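

Trifluoromethyl in place of methyl on an aromatic carbon, para to a large group, is the first change in this set that can be read as a step, and in this assay it gives a number 72.5 percentage points lower from compound 1 to compound 4 (beyond the scatter). Among the compounds shown here, with the core and the ester held constant, the step shows that the inhibition seen at the one concentration tested depends strongly on which of these two groups sits at this place, something no step among the earlier compounds could show. Nothing available here accounts for the size of this step.

The compounds shown leave open whether the loss is particular to trifluoromethyl or whether other replacements for the methyl, such as a chlorine atom, an amine or a carboxylic acid, would retain more of the inhibition seen with compound 1. They also leave open whether the same exchange at this place would have a comparable effect on the core of compound 3, which differs from the core shared by compound 1 and compound 4.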